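Replacing Fluoro with Thiazolyl on the Aryl Ring

The source may report more compounds than this note shows. Statements on the series, on what has been measured and on what is new or still open speak of the compounds shown alone.

Two compounds sharing one core have been characterised so far. Compound 1, `C[C@H](O)[C@@H](CCc1ccccc1C(F)(F)F)n1cnc2c(N)ncnc21`, gives 6.2 nM in an assay on isolated protein for inhibition of adenosine deaminase (Bos taurus), with a stated time of 5 min; a lower number here means a stronger inhibitor, a higher number a weaker inhibitor. Compound 2, `C[C@H](O)[C@@H](CCc1cccc(F)c1)n1cnc2c(N)ncnc21`, gives 1.6 nM in this assay, the lowest of the two numbers; compound 1 sits a clear step higher, beyond the usual scatter. The next compound, compound 3, `C[C@H](O)[C@@H](CCc1cccc(-c2nccs2)c1)n1cnc2c(N)ncnc21`, differs from compound 2 in a single place: 1,3-thiazol-2-yl in place of fluoro on an aromatic carbon, on an aromatic carbon of a six-membered aromatic ring of carbon only, meta to a large group. Within the data shown here, no comparable step between two measured compounds is available, so the size of the change can only be guessed. With compound 2 already at the low end of the range seen, the step from compound 2 to compound 3 is expected to be modest and towards a somewhat higher number, a 2.5-fold higher number from compound 2 to compound 3 (0.40 log units; beyond the scatter). Compound 3 is therefore estimated at 4 nM, with a plausible range from 0.8 nM to 20 nM.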

Compound 3, inhibition constant: 2.6 nM
Compound 3: the middle estimate sits 1.5-fold (0.19 log units) above what was measured; the range from low to high includes it.
By their numbers in this assay, from the lowest: compounds 2 and 3 (each within the scatter of the next); then compound 1.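

In this assay, 1,3-thiazol-2-yl in place of fluoro on this aromatic carbon, meta to a large group, gives a 1.6-fold higher number from compound 2 to compound 3 (0.21 log units; within the scatter), so a five-membered aromatic ring of five heavy atoms replaces a single fluorine with no difference that can be told from the scatter. Compound 1 and compound 2 differ in more than one place and could not show this, so this is the only reading shown of a single change at this position. No measurement shown offers an explanation for this result.

From the compounds shown here alone, whether this position would equally accept an amine, a carboxylic acid, a morpholine ring or a longer chain remains open. So does whether the 1,3-thiazol-2-yl group would give a similar number on a different carbon of the same ring.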